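This account rests on a few compounds, and the source may have more. Where it says the series, first, only, none or still open, it means among the compounds named here.

Measured compounds:
compound 1 `O=C1NC(=O)/C(=C/c2ccc(OCCC3CCCCO3)cc2)S1` in an assay for inhibition of 15-hydroxyprostaglandin dehydrogenase [NAD(+)] (Homo sapiens), read by fluorescence and spectrophotometry (on this read-out higher numbers stand for weaker inhibition and lower numbers for stronger inhibition), gives 750 nM
compound 2 `O=C1N=C(O)S/C1=C\c1ccc(OCc2ccsc2)cc1` gives 429 nM
compound 3 `COc1ccc(COc2ccc(/C=C3\SC(=O)NC3=O)cc2)cc1` gives 529 nM

Compound 2 holds the lowest of the three numbers, but its gaps to compound 3 and to compound 1 both lie within the scatter, so no order among the three can be read. Compound 4 `CC1CCC(COc2ccc(/C=C3\SC(O)=NC3=O)cc2)CC1` differs from compound 2 in that (4-methylcyclohexyl in place of thiophen-3-yl on a saturated chain carbon bound to an oxygen on an aromatic ring). Within the data shown here, one measured step touches the same place: a 1.4-fold lower number from compound 1 to compound 3 (0.15 log units; within the scatter), which stayed within the scatter. The present change is of a similar kind, a saturated ring in place of an aromatic one at that position, so no step beyond the scatter is expected in this assay. Compound 4 is therefore estimated at 500 nM, range 200 nM to 1300 nM, an expected step of a 1.2-fold higher number from compound 2 to compound 4 (0.07 log units; within the scatter).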

Compound 4, half-maximal inhibitory concentration: 52 nM
Compound 4: the middle estimate sits 9.6-fold (0.98 log units) above what was measured; measured number outside the range, below it.
By their numbers in this assay, from the lowest: compound 4; then compounds 2, 3 and 1 (each within the scatter of the next).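

In this assay, 4-methylcyclohexyl in place of thiophen-3-yl gives an 8.3-fold lower number from compound 2 to compound 4 (0.92 log units; beyond the scatter) and so shows that this position can respond beyond the scatter. The earlier step, a 1.4-fold lower number from compound 1 to compound 3 (0.15 log units; within the scatter) at the same place, did not show this, so the two ring changes do not behave alike here. No measurement available accounts for the difference.

As far as these compounds go, whether the step comes from the cyclohexyl ring itself or needs its methyl group stays open. So does the response to an amine or a carboxylic acid on that ring.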